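Methoxy to Hydroxy in a Cytotoxicity Series

The source may report more compounds than this note shows. Statements on the series, on what has been measured and on what is new or still open speak of the compounds shown alone.

Compound 1 `Cc1cc(O)cc(-c2nn(CC#N)cc2-c2ccnc(-c3ccc(Oc4ccccc4)cc3)c2)c1`: 99%
Compound 2 `COc1cc(C)cc(-c2nn(CC#N)cc2-c2ccnc(-c3ccc(N(C)C)cc3)c2)c1`: 93%

Of the compounds shown here, two have been measured so far in a functional assay on SF-295 cells (Homo sapiens) for cytotoxicity, read by sulforhodamine B assay, with a stated time of 48 h, tested at 0.001 uM; on this read-out higher numbers stand for a weaker effect at the one concentration tested and lower numbers for a stronger effect. Compound 1 gives 99% and compound 2 gives 93%. Compound 2 stands at the lower of the two numbers, yet its gap to compound 1 lies within the usual scatter of such measurements, so the two cannot be told apart on these data. Compound 3 `Cc1cc(O)cc(-c2nn(CC#N)cc2-c2ccnc(-c3ccc(N(C)C)cc3)c2)c1` differs from compound 2 in one place: hydrogen in place of methyl on an oxygen on an aromatic ring. Within the data shown here, no step between measured compounds is available, so nothing in the measured pair speaks for or against this change. Both measured compounds sit close to the top of the scale in this assay, as compound 2 at 93% shows. The step of a number 2 percentage points higher from compound 2 to compound 3 (within the scatter) is expected to stay within the scatter. Compound 3 is therefore estimated at 95%, within a range from 86% to 104%.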

Compound 3, a percentage reported as activity, at one concentration (the size of the read-out at that concentration, not a potency): 93%
Estimate against measurement, compound 3: 2 percentage points above; measured number inside the range.
By their numbers in this assay, from the lowest: compounds 2, 3 and 1 (each within the scatter of the next).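

In this assay, hydroxy in place of methoxy on the 3-methoxy-5-methylphenyl gives no change at the digits printed from compound 2 to compound 3 (within the scatter), so this change at this position has no readable effect at the one concentration tested. Compound 3 also gives the series a second comparison: dimethylamino in place of phenoxy on an aromatic carbon gives a number 6 percentage points lower from compound 1 to compound 3 (within the scatter), so that change cannot be told apart from scatter either. No other data bear on these results.

On these data alone, all three compounds read close to the top of the scale at this single concentration, so what either change does where the effect is stronger stays open. Also open, as far as these compounds go, is whether ethoxy, a longer chain on the same oxygen, or a carboxylic acid in place of the hydroxy would move the number beyond the scatter.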